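Working notes: moving the chlorine in compound 1

The source may hold more compounds than are shown below. What is called first, only, known or untested is meant among the compounds shown, and "the series" means these compounds.

The series is followed in a functional assay on 4T1 cells (Mus musculus) for cytotoxicity, read by MTT assay, with a stated time of 24 h; on this read-out lower numbers stand for stronger inhibition and higher numbers for weaker inhibition. Among the measured compounds shown here, compound 1 `O=C1/C(=C/c2ccccc2F)CN(Cc2cn(Cc3ccccc3Cl)nn2)C/C1=C\c1ccccc1F` gives 5300 nM in this assay and stands lowest of the two numbers measured so far. Compound 2 `COc1ccc(/C=C2\CN(Cc3cn(Cc4ccccc4F)nn3)C/C(=C\c3ccc(OC)cc3)C2=O)cc1` gives 39400 nM in this assay, a higher number, and the gap between the two values lies beyond the usual scatter; the two compounds differ in more than one place, so no single step can be read from them.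

Compound 3 `O=C1/C(=C/c2ccccc2F)CN(Cc2cn(Cc3cccc(Cl)c3)nn2)C/C1=C\c1ccccc1F` has not yet been measured. It differs from compound 1 only in the group on the saturated chain carbon bound to an aromatic nitrogen: 3-chlorophenyl in place of 2-chlorophenyl on a saturated chain carbon bound to an aromatic nitrogen. The shared core and the other substituents are unchanged. For the measured compounds named here, no measured pair in this set separates a 2-chlorophenyl from a 3-chlorophenyl on that carbon, so there is no precedent for the size of the step. The expected step is no larger than the usual scatter, in either direction, a 1.1-fold higher number from compound 1 to compound 3 (0.05 log units; within the scatter). Compound 3 is therefore estimated at 6000 nM in this assay, with a range from 2500 nM to 15000 nM.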

Compound 3, half-maximal inhibitory concentration: 6100 nM
The estimate for compound 3 lay 1.0-fold (0.01 log units) below the measured number, and the stated range covers the measured number.
By their numbers in this assay, from the lowest: compounds 1 and 3 (each within the scatter of the next); then compound 2.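

In this assay, 3-chlorophenyl in place of 2-chlorophenyl on a saturated chain carbon bound to an aromatic nitrogen gives a 1.2-fold higher number from compound 1 to compound 3 (0.06 log units; within the scatter) and this step lies within the scatter. Among the compounds shown here, this is the first comparison that can be read at a single place, which the earlier pair of compounds, differing in more than one place, could not provide. With the shared core and the other substituents unchanged, 2-chlorophenyl and 3-chlorophenyl cannot be told apart at this position on this read-out, and no supporting data bear on this result.

Going by these compounds, the result covers only these two chlorophenyl groups with the rest of compound 1 held fixed, so a 4-chlorophenyl, or an amine or a carboxylic acid in place of the chlorine, remains open at this position. On these data alone, whether the same small step would hold on the other substituents of compound 2 also remains open.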